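The source may report more compounds than this note shows. Statements on the series, on what has been measured and on what is new or still open speak of the compounds shown alone.

Working notes on the series. The shared core carries two arylidene arms and an N-substituent; compound 1 `C=CCn1c(=O)/c(=C\c2ccc(Cl)c(Cl)c2)[nH]c(=O)/c1=C\c1ccccc1OC` bears an allyl group there, together with a 2-methoxyphenyl arm and a 3,4-dichlorophenyl arm. In a functional assay on NCI-H1975 cells (Homo sapiens) for cytotoxicity, read by CCK-8 assay, with a stated time of 72 h (a higher number here means a weaker inhibitor, a lower number a stronger inhibitor), compound 1 gives "not active" (no number reported), so no single number stands for it. Compound 3 `C=CCn1c(=O)/c(=C\c2ccc(Cl)c(Cl)c2)[nH]c(=O)/c1=C\c1ccccc1`, which keeps the allyl group but carries an unsubstituted phenyl arm, likewise gives "not active" (no number reported) in this assay, a second entry without a number. Compound 2 `COc1ccccc1/C=c1\c(=O)[nH]/c(=C/c2cccc(Cl)c2Cl)c(=O)n1C`, with an N-methyl group and a 2,3-dichlorophenyl arm, is the only one of the three with a figure: in this assay compound 2 gives 300 nM. Among the compounds with values here, compound 2 differs from compound 1 in more than one place, so no single step between them can be drawn.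

Compound 4 `C=CCn1c(=O)/c(=C\c2cc(F)ccc2C)[nH]c(=O)/c1=C\c1ccccc1OC` is not yet measured. It differs from compound 1 in one place: 5-fluoro-2-methylphenyl in place of 3,4-dichlorophenyl on a double-bonded chain carbon bound to an aromatic carbon. Within the data shown here, no measured pair shows what this exchange does on the allyl-bearing core. Both allyl-bearing compounds measured so far, compound 1 and compound 3, returned no number in this assay, and nothing shown argues that compound 4 should break from that. The expectation is that compound 4 stays weak, with a fair chance that this assay again reports no number; if a value does come, compound 4 is estimated at 20000 nM, within 3000 nM to 100000 nM.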

Compound 4, half-maximal inhibitory concentration: 7300 nM
The estimate for compound 4 lay 2.7-fold (0.44 log units) above the measured number, and the stated range covers the measured number.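

No step can be read from compound 1 to compound 4: in this assay compound 1 gives "not active" (no number reported), while compound 4 gives 7300 nM. Nothing at hand bears on the reason for this result. The compounds shown leave open what exchanging 3,4-dichlorophenyl for 5-fluoro-2-methylphenyl does numerically on the allyl-bearing core.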